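The source may hold more compounds than are shown below. What is called first, only, known or untested is meant among the compounds shown, and "the series" means these compounds.

Compound 1, `Cc1ccccc1C1(CNC(=O)Nc2c(C(C)C)cccc2C(C)C)CCCC1`, gives 17 nM in an assay on microsomes for inhibition of acyl-CoA:cholesterol acyltransferase (Oryctolagus cuniculus); on this read-out lower numbers stand for stronger inhibition and higher numbers for weaker inhibition.
Compound 2, `Cc1ccc(C2(CNC(=O)Nc3c(C(C)C)cccc3C(C)C)CCCC2)cc1`, gives 25 nM in this assay.
Compound 3, `CC(C)c1cccc(C(C)C)c1NC(=O)NCC1(c2ccccc2C(F)(F)F)CCCC1`, gives 18 nM in this assay.

Compound 2 has the highest of these three numbers, yet the step of a 1.4-fold lower number from compound 2 to compound 3 (0.14 log units; within the scatter) and the step of a 1.5-fold higher number from compound 1 to compound 2 (0.17 log units; within the scatter) both stay within the scatter, so the three cannot be ranked. Compound 4, `CC(C)c1cccc(C(C)C)c1NC(=O)NCC1(c2ccc([N+](=O)[O-])cc2)CCCC1`, is not yet measured. It differs from compound 2 as follows: nitro in place of methyl on an aromatic carbon. Going by the values given here, no measured step exchanges methyl for nitro; the steps that touch the same phenyl group are a 1.5-fold higher number from compound 1 to compound 2 (0.17 log units; within the scatter) and a 1.4-fold lower number from compound 2 to compound 3 (0.14 log units; within the scatter), both small, suggesting that the phenyl tolerates varied substituents without large effects. Because a 1.4-fold lower number from compound 2 to compound 3 (0.14 log units; within the scatter) and a 1.5-fold higher number from compound 1 to compound 2 (0.17 log units; within the scatter) stay within the scatter, compound 4 is expected to sit close to compound 2, with a step of a 1.4-fold higher number from compound 2 to compound 4 (0.15 log units; within the scatter) that is not beyond the scatter. In this assay compound 4 is estimated at 35 nM, with a range from 12 nM to 100 nM.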

Compound 4, half-maximal inhibitory concentration: 131 nM
Beside the measured number, compound 4's estimate is 3.7-fold (0.57 log units) below it, outside the stated range (above it).
By their numbers in this assay, from the lowest: compounds 1, 3 and 2 (each within the scatter of the next); then compound 4.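

Going by these compounds alone, compound 4 shows that this aromatic carbon, para to a large group, does not accept every substituent equally: in this assay, nitro in place of methyl gives a 5.2-fold higher number from compound 2 to compound 4 (0.72 log units; beyond the scatter) and is the first single-group change here to go beyond the scatter. The other two steps, a 7.3-fold higher number from compound 3 to compound 4 (0.86 log units; beyond the scatter) and a 7.7-fold higher number from compound 1 to compound 4 (0.89 log units; beyond the scatter), are also beyond the scatter and make compound 4 the weakest inhibitor of the four, although these steps also change where the substituent sits on the phenyl ring. Nothing available explains why the number rises with nitro.

On these data alone, it remains open whether this rise is particular to nitro or would also appear with an amine, a nitrile or a carboxylic acid on the same carbon. As far as these compounds go, it is also open how nitro would behave at the place held by methyl in compound 1.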